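The source may report more compounds than this note shows. Statements on the series, on what has been measured and on what is new or still open speak of the compounds shown alone.

Measured in an ADME assay on microsomes from liver (Mus musculus) for metabolic stability, read by LC-MS, with NADPH named in the record, with a stated time of 60 min, tested at 1 uM, in the absence of a further agent; on this read-out lower numbers stand for a less stable compound and higher numbers for a more stable compound:
- compound 1 `COc1ccc(-c2c(C)nc3c(N4CC[C@@H](NC(C)=O)C4)cc(C)nn23)cc1OC`: > 95%
- compound 2 `COc1ccc(-c2c(C)nc3c(N4CC[C@@H](NC(C)=O)C4)cc(C)nn23)cc1F`: > 95%
- compound 3 `CC(=O)N[C@@H]1CCN(c2cc(C)nn3c(-c4ccco4)c(C)nc23)C1`: > 95%

Compound 1 stands at a limit and not at a number, and so do the two other compounds: the limit of > 95% in this assay, at which 3 of the 3 values shown sit.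

Next in line is compound 4 `COc1ccc(-c2c(C)nc3c(N4CC[C@@H](NC(=O)COc5ccccc5)C4)cc(C)nn23)cc1OC`. The change from compound 1 is phenoxy in place of hydrogen on a saturated chain carbon bound to a carbonyl carbon, which turns acetamido into ((phenoxymethyl)carbonyl)amino.

Three measured steps are available: a step that the two limits leave unreadable from compound 1 to compound 2, a step that the two limits leave unreadable from compound 1 to compound 3 and a step that the two limits leave unreadable from compound 2 to compound 3. None has a readable size. All three also concern the aromatic group on the shared core and leave the acetamido group untouched, so they bear only weakly on this change. The series therefore offers no measured size for a change at the acetamido group.

With compound 1 at > 95%, a limit, only a step towards lower numbers could be read. The expected outcome is a number at least 15 percentage points lower from compound 1 to compound 4 (beyond the scatter), towards a less stable compound, and this is uncertain in size. For compound 4 the estimated value is 80%, with an expected range from 50% to 98%.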

Compound 4, percent of the compound remaining: > 95%
Compound 4: a limit, no number; the forecaster's own chance of this, stated with the estimate: 35%; middle value at least 15 percentage points away from the limit.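

In this assay compound 4 gives > 95%, a limit and not a number. No step can be read between compound 1 and compound 4, which share that limit: the limit of > 95% in this assay, at which 4 of the 4 values shown sit.

The compounds shown leave open whether phenoxy in place of hydrogen, or any change to the aromatic group, alters the percent of compound remaining.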